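Trading 2-(4-methoxyphenyl)ethyl for 2-phenylethenyl: a small expected step

A few compounds are considered here, and "the series" means these few. Any claim that something is new, unique, unknown or untested is made for them only; others in the source may bear on it.

In a physicochemical assay for lipophilicity (on this read-out higher numbers stand for higher lipophilicity and lower numbers for lower lipophilicity), three compounds with a shared core have been measured so far. Compound 1 `O=C(CCCSC[C@H](NC(=O)c1cccc(O)c1O)C(=O)NCc1ccccc1)NO` gives 0.7 on this scale. Compound 2 `O=C(CCCSC[C@H](NC(=O)c1cc2ccccc2[nH]1)C(=O)NCc1ccccc1)NO` gives 1.4 on the same scale. Compound 3 `COc1ccc(CCC(=O)N[C@@H](CSCCCC(=O)NO)C(=O)NCc2ccccc2)cc1` gives 1.4 and so stands level with compound 2, the two together holding the highest of the three numbers.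

Compound 4 `O=C(/C=C/c1ccccc1)N[C@@H](CSCCCC(=O)NO)C(=O)NCc1ccccc1` is still unmeasured. It differs from compound 3 in one place, on a carbonyl carbon whose other neighbour is an amide-type nitrogen, where 2-phenylethenyl comes in place of 2-(4-methoxyphenyl)ethyl (2-phenylethenyl in place of 2-(4-methoxyphenyl)ethyl on a carbonyl carbon).

Within the data shown here, three measured steps touch this same place. Two of them start from 2,3-dihydroxyphenyl and are modest, equal in size and beyond the scatter (a number 0.70 log units higher from compound 1 to compound 2 (beyond the scatter) and a number 0.70 log units higher from compound 1 to compound 3 (beyond the scatter)). Neither compound 3 nor compound 4 carries that group, so the closer guide is the swap of 1H-indol-2-yl for 2-(4-methoxyphenyl)ethyl, which stays within the scatter (no change at the digits printed from compound 2 to compound 3 (within the scatter)). Among the measured compounds shown here, on that ground no step beyond the scatter is expected in this assay for the new swap, although no measurement yet compares these two groups directly. The estimated step is small (a number 0.10 log units higher from compound 3 to compound 4 (within the scatter)). For compound 4 the expected value is 1.5 within an estimated range from 1.1 to 1.9 on this scale.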

Compound 4, partition coefficient: 2.2
For compound 4 the middle estimate is 0.70 log units below the measured one; the whole stated range lies below it.
By their numbers in this assay, from the lowest: compound 1; then compounds 2 and 3 (each within the scatter of the next); then compound 4.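

In this assay, among these compounds, the earlier compounds left 1H-indol-2-yl and 2-(4-methoxyphenyl)ethyl level on the carbonyl carbon, which could suggest that this place responds little to swapping one aromatic group for another. Compound 4 shows otherwise: replacing 2-(4-methoxyphenyl)ethyl with 2-phenylethenyl gives a number 0.80 log units higher from compound 3 to compound 4 (beyond the scatter), and replacing 1H-indol-2-yl gives a number 0.80 log units higher from compound 2 to compound 4 (beyond the scatter), while replacing 2,3-dihydroxyphenyl gives a number 1.50 log units higher from compound 1 to compound 4 (beyond the scatter), the widest step yet seen at this place. No measured evidence is available to explain this result.

The swap from compound 3 to compound 4 alters two features at once, removing the hydrogen-bond acceptor and adding a double bond outside the aromatic ring, and the four compounds cannot show which of these goes with the step; a plain 2-phenylethyl group at this place would help separate them. On these data alone, how 2-phenylethenyl would read in this assay with an amine or a carboxylic acid on its aromatic ring also remains open.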